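Swapping the Ring on the Sulfonyl Sulfur of Compound 1

The source may report more compounds than this note shows. Statements on the series, on what has been measured and on what is new or still open speak of the compounds shown alone.

Compound 1 `CC(C)(C)C1CCN(S(=O)(=O)c2ccc(NC(=O)c3ccc([N+](=O)[O-])o3)cc2)CC1` in an ADME assay on IMR-90 cells (Homo sapiens) for cytotoxicity, read by CellTiter-Blue, with a stated time of 46 h (on this read-out lower numbers stand for an effect already at smaller amounts and higher numbers for an effect only at larger amounts of compound), gives > 25000 nM, a limit of the assay.
Compound 2 `O=C(Nc1ccc(S(=O)(=O)N2CCC(O)CC2)cc1)c1ccc([N+](=O)[O-])o1` in this assay gives > 25000 nM, also a limit.
Compound 3 `O=C(Nc1ccc(S(=O)(=O)N2CCC(F)CC2)cc1)c1ccc([N+](=O)[O-])o1` in this assay gives > 25000 nM, again a limit.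

In this assay compound 1 stands only at a limit, and the same holds for the other two measured compounds, so the limit of > 25000 nM in this assay, at which 3 of the 3 values shown sit, is all the numbers show. The three measured steps are a step that the two limits leave unreadable from compound 1 to compound 2, a step that the two limits leave unreadable from compound 1 to compound 3 and a step that the two limits leave unreadable from compound 2 to compound 3, none with a readable size. Among the compounds with values here, compound 4 `O=C(Nc1ccc(S(=O)(=O)c2ccccc2)cc1)c1ccc([N+](=O)[O-])o1` arises through (phenyl in place of 4-(tert-butyl)piperidin-1-yl on a sulfonyl sulfur); this change at the sulfonyl sulfur has no measured counterpart, since all three steps concern the saturated ring carbon. Because every measured value sits at the limit of > 25000 nM in this assay, at which 3 of the 3 values shown sit, no step beyond the scatter is expected, and compound 4 is expected to give 30000 nM (range 15000 nM to 60000 nM), a step that the limit leaves unreadable from compound 1 to compound 4.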

Compound 4, half-maximal effective concentration: > 25000 nM
Compound 4 gave a limit, no number; the forecaster's own chance of this, stated with the estimate: 85%; the middle value lies beyond the limit too.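

Within the data shown here, compound 4 stops at a limit, as do compound 1, compound 2 and compound 3, so no step between any of them can be read: the limit of > 25000 nM in this assay, at which 4 of the 4 values shown sit. The compounds shown leave open what concentration of each would produce an effect in this assay.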